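The source may report more compounds than this note shows. Statements on the series, on what has been measured and on what is new or still open speak of the compounds shown alone.

Measured in a functional assay on cells (Splenocyte, Mus musculus, strain BALB/c) for inhibition, read by scintillation counting and thymidine incorporation, with a stated time of 72 h; a higher number here means a weaker inhibitor, a lower number a stronger inhibitor:
compound 1, `CC(/C=N/Nc1ccc([N+](=O)[O-])cc1)=N\NC(=O)c1ccc(N)cc1`: > 12000 nM, a limit of the assay rather than a number.
compound 2, `CC(/C=N/Nc1ccc([N+](=O)[O-])cc1)=N\NC(=O)c1ccc(O)cc1`: 1510 nM.
compound 3, `CC(/C=N/Nc1ccc([N+](=O)[O-])cc1)=N\NC(=O)c1ccc([N+](=O)[O-])cc1`: 980 nM.

Compound 3 gives the lowest of the two numbers, though a 1.5-fold lower number from compound 2 to compound 3 (0.19 log units; within the scatter) is within the scatter, so the two stand together. Compound 4, `COc1ccc(C(=O)N/N=C(C)/C=N/Nc2ccc([N+](=O)[O-])cc2)cc1`, is not yet measured; it differs from compound 3 by methoxy in place of nitro on an aromatic carbon. Among the measured compounds shown here, the steps that bear on this change are an at least 12-fold lower number from compound 1 to compound 3 (1.08 log units; beyond the scatter) and a 1.5-fold lower number from compound 2 to compound 3 (0.19 log units; within the scatter): the amino analogue sits only at the limit (the limit of > 12000 nM in this assay, at which 1 of the 3 values shown sits), while the hydroxy analogue stays close to compound 3. The methoxy analogue is expected to fall between these outcomes, so a step of a 2.6-fold higher number from compound 3 to compound 4 (0.41 log units; beyond the scatter) towards a higher number is expected. Compound 4 is estimated at 2500 nM, between 700 nM and 12000 nM.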

Compound 4, half-maximal inhibitory concentration: > 12000 nM
Compound 4: only a limit was reported; the forecaster's own chance of this, stated with the estimate: 20%; middle value at least 4.8-fold (0.68 log units) from the limit.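

In this assay, methyl on the oxygen of compound 2 separates two analogues that looked alike in kind: an at least 7.9-fold higher number from compound 2 to compound 4 (0.90 log units; beyond the scatter), and an at least 12-fold higher number from compound 3 to compound 4 (1.08 log units; beyond the scatter). The methoxy group therefore sides with amino, not with hydroxy or nitro, so an oxygen on this aromatic carbon does not by itself keep the number low. Compound 4 gives > 12000 nM, which is a limit and not a number, and the step between compound 1 and compound 4 cannot be read: the limit of > 12000 nM in this assay, at which 2 of the 4 values shown sit.

From the compounds shown here alone, how far compound 1 and compound 4 lie past that limit stays open. So does whether a chloro group, a carboxylic acid or a longer alkoxy chain here would side with compound 2 and compound 3.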